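Moving the bromine on the amide-bound ring

The source may hold more compounds than are shown below. What is called first, only, known or untested is meant among the compounds shown, and "the series" means these compounds.

The three measured compounds share one core and differ only in the group on the ring attached to the amide nitrogen. In an assay on CHO cells, read by calcium flux (a lower number here means a stronger inhibitor, a higher number a weaker inhibitor), compound 3 `O=C(Nc1ccc(Br)cc1)c1csc(Cc2c(Cl)cccc2Cl)n1` gives 400 nM, the lowest of the two numbers recorded. Compound 1 `CC(C)(C)c1ccc(NC(=O)c2csc(Cc3c(Cl)cccc3Cl)n2)cc1` gives 570 nM in this assay, and the step of a 1.4-fold lower number from compound 1 to compound 3 (0.15 log units; within the scatter) lies within the scatter, so the two cannot be told apart. Compound 2 `CN(C)c1ccc(NC(=O)c2csc(Cc3c(Cl)cccc3Cl)n2)cc1` returns only a limit of the assay, > 4000 nM, in this assay. The steps of an at least 7.0-fold higher number from compound 1 to compound 2 (0.84 log units; beyond the scatter) and an at least 10-fold lower number from compound 2 to compound 3 (1.00 log units; beyond the scatter) are the only ones beyond the scatter, and both involve the dimethylamino compound.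

Compound 4 `O=C(Nc1ccccc1Br)c1csc(Cc2c(Cl)cccc2Cl)n1` is not yet measured. It differs from compound 3 by 2-bromophenyl in place of 4-bromophenyl on an amide-type nitrogen. Among the compounds with values here, none of the measured steps moves the bromine around the ring; all of them swap the group at the same place, so no measured step bears directly on this change. The expected step of a 2.3-fold higher number from compound 3 to compound 4 (0.35 log units; beyond the scatter) is therefore uncertain, and an unchanged or weaker result is expected rather than a stronger one. Compound 4 is estimated at 900 nM, within 300 nM to 4000 nM.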

Compound 4, half-maximal inhibitory concentration: > 4000 nM
Compound 4 was reported as a limit; the forecaster's own chance of this, stated with the estimate: 15%; middle value at least 4.4-fold (0.64 log units) from the limit.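

Moving the bromine, with the same atoms joined differently, gives an at least 10-fold higher number from compound 3 to compound 4 (1.00 log units; beyond the scatter) in this assay. Within the data shown here, the earlier steps all swapped one group for another at a single spot on the ring, so they could show only that the choice of group can matter; this step shows that at this place, on the amide-type nitrogen, where the same bromine sits matters as well. Compound 4 returns a limit of the assay rather than a number, so the step gives only a minimum size: the limit of > 4000 nM in this assay, at which 2 of the 4 values shown sit.

On these data alone, it remains open whether a fluoro or a methyl group where the 2-bromophenyl group carries its bromine would give the same result, or whether the loss belongs to bromine alone. Also open, as far as these compounds go, is what an amine or a carboxylic acid would do at the spot the bromine holds in compound 3.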